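Pyrrolidin-1-yl to Piperidin-1-yl, Tested Twice on One Scaffold

The source may report more compounds than this note shows. Statements on the series, on what has been measured and on what is new or still open speak of the compounds shown alone.

Three compounds have been measured in a functional assay on A549 cells (Homo sapiens) for inhibition, read by MTT assay, with a stated time of 72 h; a lower number here means a stronger inhibitor, a higher number a weaker inhibitor:
Compound 1, `COc1cc2c(Oc3ccc(NC(=O)c4nn(-c5ccccc5C(F)(F)F)c(=O)cc4C)cc3F)ccnc2cc1OCCCN1CCCC1`, gives 130 nM.
Compound 2, `COc1cc2c(Oc3ccc(NC(=O)c4nn(-c5ccccc5C(F)(F)F)c(=O)cc4C)cc3F)ccnc2cc1OCCCN1CCCCC1`, gives 140 nM.
Compound 3, `COc1cc2c(Oc3ccc(NC(=O)c4nn(-c5ccccc5OC(F)(F)F)c(=O)cc4C)cc3F)ccnc2cc1OCCCN1CCCC1`, gives 140 nM.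

The change from compound 1 to compound 2 is piperidin-1-yl in place of pyrrolidin-1-yl on a saturated chain carbon, three bonds along the chain from an oxygen on an aromatic ring. Its step was a 1.1-fold higher number from compound 1 to compound 2 (0.03 log units; within the scatter). The two cores differ by trifluoromethoxy in place of trifluoromethyl on an aromatic carbon, and that step was a 1.1-fold higher number from compound 1 to compound 3 (0.03 log units; within the scatter). In this assay compound 3 stands level with compound 2 at the digits reported.

Compound 4, `COc1cc2c(Oc3ccc(NC(=O)c4nn(-c5ccccc5OC(F)(F)F)c(=O)cc4C)cc3F)ccnc2cc1OCCCN1CCCCC1`, has not yet been measured. It differs from compound 3 by piperidin-1-yl in place of pyrrolidin-1-yl on a saturated chain carbon, three bonds along the chain from an oxygen on an aromatic ring. The place is described in the same words as for the step from compound 1 to compound 2, so this is the same change, made on the core of compound 3 instead of the core of compound 1.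

Because the earlier step was a 1.1-fold higher number from compound 1 to compound 2 (0.03 log units; within the scatter), compound 4 is expected to show a 1.1-fold higher number from compound 3 to compound 4 (0.03 log units; within the scatter). This expectation rests only on compound 1 and compound 2, where the same change stayed within the scatter. Compound 4 is therefore estimated at 150 nM, with a likely range from 80 nM to 280 nM.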

Compound 4, half-maximal inhibitory concentration: 120 nM
Compound 4: middle estimate off by 1.3-fold (0.10 log units), on the high side, within the range that was stated.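

Among the compounds shown here, on the core of compound 3, piperidin-1-yl in place of pyrrolidin-1-yl gave a 1.2-fold lower number from compound 3 to compound 4 (0.07 log units; within the scatter) in this assay, and this agrees with the same change on the core of compound 1: the same change on two cores in this assay, a 1.1-fold higher number (0.03 log units; within the scatter) from compound 1 to compound 2 and a 1.2-fold lower number (0.07 log units; within the scatter) from compound 3 to compound 4, 1.3-fold (0.10 log units) apart, within the scatter of two such steps Trifluoromethoxy in place of trifluoromethyl, made on the piperidin-1-yl side, gave a 1.2-fold lower number from compound 2 to compound 4 (0.07 log units; within the scatter), and this also agrees with its earlier counterpart: the same change on two cores in this assay, a 1.1-fold higher number (0.03 log units; within the scatter) from compound 1 to compound 3 and a 1.2-fold lower number (0.07 log units; within the scatter) from compound 2 to compound 4, 1.3-fold (0.10 log units) apart, within the scatter of two such steps Both changes therefore carried between these two cores with no readable shift, but every step lies within the scatter, so this shows only that neither change made a measurable difference here, not that any real effect adds up from core to core or that the same would hold on other cores.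

The compounds shown leave open whether another amine, such as morpholin-4-yl or 4-methylpiperazin-1-yl, or a shorter or longer chain would move the number beyond the scatter. The same question stands for a nitrile or a chlorine in place of trifluoromethyl.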